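The source may hold more compounds than are shown below. What is called first, only, known or untested is meant among the compounds shown, and "the series" means these compounds.

Measured compounds:
- Compound 1 `OC[C@H]1O[C@@H](n2cnc3c(NCc4ccccc4F)ncnc32)[C@H](O)[C@@H]1O`: 33200 nM
- Compound 2 `OC[C@H]1O[C@@H](n2cnc3c(NCc4ccc(Cl)cc4)ncnc32)[C@H](O)[C@@H]1O`: 218000 nM
- Compound 3 `OC[C@H]1O[C@@H](n2cnc3c(NCc4ccc(F)cc4Cl)ncnc32)[C@H](O)[C@@H]1O`: 15600 nM

These three compounds were tested in a functional assay on K562 cells (Homo sapiens) for antiproliferative activity, with a stated time of 72 h; on this read-out higher numbers stand for weaker inhibition and lower numbers for stronger inhibition. They share a core and differ only in the aromatic group on a saturated chain carbon bound to a nitrogen on an aromatic ring. Compound 3 has the lowest number of the three, 15600 nM, and is the most potent of the set. The measured steps to it are a 2.1-fold lower number from compound 1 to compound 3 (0.33 log units; beyond the scatter) and a 14-fold lower number from compound 2 to compound 3 (1.15 log units; beyond the scatter).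

Compound 4 `OC[C@H]1O[C@@H](n2cnc3c(NCc4cccc(O)c4O)ncnc32)[C@H](O)[C@@H]1O` has not yet been measured. It differs from compound 3 as follows: 2,3-dihydroxyphenyl in place of 2-chloro-4-fluorophenyl on a saturated chain carbon bound to a nitrogen on an aromatic ring. For the measured compounds named here, no measured step introduces a 2,3-dihydroxyphenyl group, so none of them measures this change directly. Going by the values given here, the available steps show only how far a swap at this place has moved the number so far, from the modest 2.1-fold lower number from compound 1 to compound 3 (0.33 log units; beyond the scatter) to the large 14-fold lower number from compound 2 to compound 3 (1.15 log units; beyond the scatter), with a 6.6-fold higher number from compound 1 to compound 2 (0.82 log units; beyond the scatter) in between. Compound 3 already sits at the low end of this small range, so a modest move towards a higher number seems the likeliest outcome, though a large one cannot be excluded. In this assay the expected change is a 2.6-fold higher number from compound 3 to compound 4 (0.41 log units; beyond the scatter). Compound 4 is estimated at 40000 nM, with an expected range of 12000 nM to 150000 nM.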

Compound 4, half-maximal inhibitory concentration: 25800 nM
Compound 4: middle estimate off by 1.6-fold (0.19 log units), on the high side; the range from low to high includes it.
By their numbers in this assay, from the lowest: compounds 3, 4 and 1 (each within the scatter of the next, the first and the last beyond it); then compound 2.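

In this assay, replacing 2-chloro-4-fluorophenyl, a group with no hydrogen-bond donors or acceptors, by 2,3-dihydroxyphenyl, which has both, gives a step that stays within the scatter: a 1.7-fold higher number from compound 3 to compound 4 (0.22 log units; within the scatter). The same holds against the 2-fluorophenyl group, with a 1.3-fold lower number from compound 1 to compound 4 (0.11 log units; within the scatter), while the step from 4-chlorophenyl remains clearly larger, with an 8.4-fold lower number from compound 2 to compound 4 (0.93 log units; beyond the scatter); among these four compounds, then, a halogen on the benzyl ring is not needed to keep the number in the range of compound 1 and compound 3, and compound 2 alone stands apart. Nothing available here explains why two such different groups give numbers within the scatter of each other, or why compound 2 differs from the rest.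

The compounds shown leave open whether both hydroxyl groups of compound 4 contribute to its number, which a phenyl ring bearing a single hydroxyl or a methoxy group would help to settle. They also leave open how a benzyl group carrying an amine or a carboxylic acid would read at this place, and whether any group here can bring the number far below that of compound 3.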